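The source may report more compounds than this note shows. Statements on the series, on what has been measured and on what is new or still open speak of the compounds shown alone.

Compound 2 `C[C@H]1[C@H](NCc2sccc2-c2ccsc2)C[C@H]2C[C@@H]1C2(C)C` is a small amine built on the shared core, and in an ADME assay on MDCK cells (Canis lupus familiaris) for cytotoxicity, read by microscopy, with a stated time of 48 h (a higher number here means that more compound is tolerated, a lower number that less compound is tolerated), compound 2 gives 12500 nM. Among the numbers measured, this is the lowest of two; compound 1 `C[C@H]1[C@H](NCc2ccsc2)C[C@H]2C[C@@H]1C2(C)C` gives 50000 nM in this assay, a higher number, which lies beyond the scatter. Compound 3 `C[C@H]1[C@H](NCc2cncs2)C[C@H]2C[C@@H]1C2(C)C` is measured only to a limit in this assay: compound 3 gives > 100000 nM. Going by the values given here, the one step measured, an at least 2.0-fold higher number from compound 1 to compound 3 (0.30 log units; that floor lies within the scatter), exchanges the ring attached to the saturated chain carbon and says nothing directly about the change at hand, and its size is bounded by the limit of > 100000 nM in this assay, at which 1 of the 3 values shown sits. Compound 4 `CCCc1ccsc1CN[C@@H]1C[C@H]2C[C@@H]([C@H]1C)C2(C)C` differs from compound 2 by propyl in place of thiophen-3-yl on an aromatic carbon. Among the compounds with values here, no measured step bears on this change; what is available is the gap between compound 2 and compound 1, which shows that removing the thiophen-3-yl from that aromatic carbon gives a higher number. Propyl is smaller than thiophen-3-yl but larger than a hydrogen, so compound 4 is expected to sit between compound 2 and compound 1, with an expected step of a 2.0-fold higher number from compound 2 to compound 4 (0.30 log units; within the scatter). Compound 4 is therefore estimated at 25000 nM, within a range of 8000 nM to 80000 nM.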

Compound 4, minimum cytotoxic concentration: 50000 nM
The estimate for compound 4 lay 2.0-fold (0.30 log units) below the measured number; low and high end bracket the measured number.
By their numbers in this assay, from the lowest: compound 2; then compounds 1 and 4 (each within the scatter of the next). At a limit, above all of these: compound 3.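

Going by these compounds alone, the step of a 4.0-fold higher number from compound 2 to compound 4 (0.60 log units; beyond the scatter) gives the first direct reading in this assay at this aromatic carbon, two ring bonds from the ring sulfur. The earlier compounds shown here held no pair that differed only here, so the group on this carbon had not been tested on its own. The step now shows that an open propyl chain in place of the thiophen-3-yl ring gives a modest rise in the tolerated concentration, and no measurement shown here accounts for that rise.

The compounds shown leave open whether the rise follows from losing the ring, losing its sulfur or changing the group's size. A phenyl ring, a shorter ethyl chain or a longer pentyl chain on the same carbon would help to separate these readings.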